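Working notes on compound 1 and a carbamoyl variant

A few compounds are considered here, and "the series" means these few. Any claim that something is new, unique, unknown or untested is made for them only; others in the source may bear on it.

Within the data shown here, compound 1 `CCCCN(c1nc2ccccc2o1)[C@H](C)c1ccc(-c2ccccc2-c2nnn[nH]2)cc1` holds the higher of the two numbers measured so far in an ADME assay on the whole organism (plasma, Macaca fascicularis) for protein binding, read by LC-MS, using equilibrium dialysis and cassette dosing, with a stated time of 24 h, at a dose of 1 mg/kg by the oral route; a higher number here means a larger unbound share of the compound, a lower number a smaller unbound share: compound 1 gives 0.000713. Among the measured compounds shown here, compound 2 `Cc1ccc(-c2nc(=O)o[nH]2)c(-c2ccc([C@@H](C)N(CC3CC3)c3nc4c(C(=O)O)cccc4o3)cc2)c1`, the only other measured compound, gives 0.00023 in this assay, a number beyond the scatter below that of compound 1; the two structures differ in several places at once, so the pair shows no more than that.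

Compound 3 `CCCCN(c1nc2c(C(=O)NS(C)(=O)=O)cccc2o1)[C@H](C)c1ccc(-c2ccccc2-c2nnn[nH]2)cc1` keeps the whole of compound 1 and adds a single group: (methylsulfonyl)carbamoyl in place of hydrogen on an aromatic carbon. For the measured compounds named here, no pair of measured compounds isolates this change, so the size of the step rests on expectation alone. The expected step from compound 1 to compound 3 is a modest fall, a 1.8-fold lower number from compound 1 to compound 3 (0.25 log units; within the scatter), near the edge of the usual scatter, since compound 2, which carries a carboxylic acid, sits at 0.00023.

Compound 3 is therefore estimated at 0.0004 in this assay, with a range from 0.00015 to 0.0011.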

Compound 3, unbound fraction: 0.00103
Compound 3: the middle estimate sits 2.6-fold (0.41 log units) below what was measured, within the range that was stated.
By their numbers in this assay, from the lowest: compound 2; then compounds 1 and 3 (each within the scatter of the next).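

Working from the one step in the series that isolates a single place, (methylsulfonyl)carbamoyl in place of hydrogen on an aromatic carbon of the core of compound 1 gives a 1.4-fold higher number from compound 1 to compound 3 (0.16 log units; within the scatter). In this assay, then, this position takes a group of 7 heavy atoms with no change that can be told from the scatter, and the unbound fractions of the two compounds cannot be ranked. No measurement at hand bears on why the number holds at this level.

Still open, as far as these compounds go, is whether a carboxylic acid or an amine on the same aromatic carbon of the core of compound 1 would also stay within the scatter. Equally open, from the compounds shown here alone, is whether (methylsulfonyl)carbamoyl would give a similar step on another carbon of that six-membered ring, or with a longer chain on the nitrogen.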